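The compounds below may be only part of what the source reports. "The series", "measured", "known", "first", "only" and "open" are said of these compounds alone.

Compound 1 `Fc1ccc(-c2cn(-c3ccnc4cc(Cl)ccc34)nn2)cc1`: > 3080000 nM
Compound 2 `COc1ccc(C(=O)OCCCc2cn(-c3ccnc4cc(Cl)ccc34)nn2)cc1`: 347000 nM
Compound 3 `COc1c(F)c(F)cc(C(=O)OCc2cn(-c3ccnc4cc(Cl)ccc34)nn2)c1F`: > 2230000 nM

In an ADME assay on HepG2 cells (Homo sapiens) for cytotoxicity, read by MTT assay, with a stated time of 24 h (on this read-out lower numbers stand for higher toxicity in this test and higher numbers for lower toxicity in this test), compound 1 gives > 3080000 nM, which is a limit of the assay and not a number; it is the limit of > 3080000 nM in this assay, at which 1 of the 3 values shown sits. Compound 3 also sits at a limit, namely (the limit of > 2230000 nM in this assay, at which 1 of the 3 values shown sits). Compound 2 alone gives a number, 347000 nM. Compound 1 thus stands at the less toxic end of what these three show. Compound 4 `OC1CCN(Cc2cn(-c3ccnc4cc(Cl)ccc34)nn2)CC1` is not yet measured; it differs from compound 1 by (4-hydroxypiperidin-1-yl)methyl in place of 4-fluorophenyl on an aromatic carbon. Among the measured compounds shown here, no step between measured compounds is available for this change, so its size is uncertain; a step within the scatter, or at most a modest move toward higher toxicity, is expected. Compound 4 is expected to give about 1500000 nM, in a range from 300000 nM to 5000000 nM. The expected step is an at least 2.0-fold lower number from compound 1 to compound 4 (0.31 log units; beyond the scatter).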

Compound 4, half-maximal cytotoxic concentration: 930000 nM
For compound 4 the middle estimate is 1.6-fold (0.21 log units) above the measured one; the range from low to high includes it.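

Placing (4-hydroxypiperidin-1-yl)methyl in place of 4-fluorophenyl on this aromatic carbon gives an at least 3.3-fold lower number from compound 1 to compound 4 (0.52 log units; beyond the scatter) in this assay. This shows that the group at this position can move the read-out beyond the scatter, toward higher toxicity in this test. The true size of the step stays unknown, as compound 1 gives a limit and not a number: the limit of > 3080000 nM in this assay, at which 1 of the 4 values shown sits.

As far as these compounds go, the change replaces the whole group at once, so it remains open which part of it matters. A plain piperidine without the hydroxyl, or a morpholine, at this carbon could begin to separate these parts.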